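The compounds below may be only part of what the source reports. "The series", "measured", "known", "first", "only" and "open" are said of these compounds alone.

Of the compounds shown here, three built on one shared core have been measured in a functional assay on RAW264.7 cells (Mus musculus) for inhibition, read by Griess assay, with stated times of 1 h and 24 h; a higher number here means a weaker inhibitor, a lower number a stronger inhibitor. Compound 1 `O=C1CC(c2ccccc2OCc2ccccc2)Oc2ccccc21` gives 18900 nM, compound 2 `CC(C)=CCOc1ccccc1C1CC(=O)c2ccccc2O1` gives 32700 nM, and compound 3 `COc1ccccc1C1CC(=O)c2ccccc2O1` gives 47300 nM. On these numbers compound 2 sits in the middle, yet its gap to compound 1 and its gap to compound 3 both lie within the scatter. Compound 4 `CCCCCOc1ccccc1C1CC(=O)c2ccccc2O1` differs from compound 2 by butyl in place of 2-methylprop-1-en-1-yl on a saturated chain carbon bound to an oxygen on an aromatic ring. The steps that touch this same place were small: a 1.7-fold higher number from compound 1 to compound 2 (0.24 log units; within the scatter) and a 1.4-fold higher number from compound 2 to compound 3 (0.16 log units; within the scatter), with only a 2.5-fold higher number from compound 1 to compound 3 (0.40 log units; beyond the scatter) reaching beyond the scatter. A change of similar size at this place is therefore expected to move the number little, if at all, in this assay. Compound 4 is estimated at 35000 nM, most likely between 15000 nM and 80000 nM. This amounts to an expected 1.1-fold higher number from compound 2 to compound 4 (0.03 log units; within the scatter).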

Compound 4, half-maximal inhibitory concentration: 39200 nM
The estimate for compound 4 lay 1.1-fold (0.05 log units) below the measured number; measured number inside the range.
By their numbers in this assay, from the lowest: compounds 1, 2, 4 and 3 (each within the scatter of the next, the first and the last beyond it).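

In this assay, butyl in place of 2-methylprop-1-en-1-yl gives a 1.2-fold higher number from compound 2 to compound 4 (0.08 log units; within the scatter), so losing the double bond outside aromatic rings makes no readable difference at this place. Butyl also stays level with hydrogen, at a 1.2-fold lower number from compound 3 to compound 4 (0.08 log units; within the scatter), while phenyl alone stands apart from it, with a 2.1-fold higher number from compound 1 to compound 4 (0.32 log units; beyond the scatter). No available evidence bears on this result. Still open, from the compounds shown here alone, is whether a chain ending in an amine or a carboxylic acid would shift the number at this place. Also open, going by these compounds, is whether a longer chain, such as octyl, would stay level with butyl.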